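A few compounds are considered here, and "the series" means these few. Any claim that something is new, unique, unknown or untested is made for them only; others in the source may bear on it.

Compounds measured in a functional assay on RAW264.7 cells (Mus musculus) for inhibition, read by Griess assay, with stated times of 2 h and 24 h; a lower number here means a stronger inhibitor, a higher number a weaker inhibitor:
Compound 1 `COc1ccc([C@@H]2CC(=O)c3c(O)cc(OCc4cn(Cc5ccc(C(F)(F)F)cc5)nn4)cc3O2)cc1O` — 17700 nM
Compound 2 `COc1ccc([C@@H]2CC(=O)c3c(O)cc(OCc4cn(C5CCCC5)nn4)cc3O2)cc1O` — 10500 nM
Compound 3 `COc1ccc([C@@H]2CC(=O)c3c(O)cc(OCc4cn(Cc5cccc(Cl)c5)nn4)cc3O2)cc1O` — 18200 nM

All three share one core and differ only in the group on the aromatic nitrogen of the triazole. Compound 3 stands apart from compound 1 by a 1.0-fold higher number from compound 1 to compound 3 (0.01 log units; within the scatter) and from compound 2 by a 1.7-fold higher number from compound 2 to compound 3 (0.24 log units; within the scatter), so the three numbers sit together, none separated from another beyond the scatter.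

Compound 4 `COc1ccc([C@@H]2CC(=O)c3c(O)cc(OCc4cn(Cc5ccccc5C(F)(F)F)nn4)cc3O2)cc1O` carries 2-(trifluoromethyl)phenyl in place of 3-chlorophenyl on a saturated chain carbon bound to an aromatic nitrogen. Among the compounds with values here, the one measured step that bears on this place is the exchange of one aryl group for another on the same saturated carbon, from compound 1 to compound 3, which gave a 1.0-fold higher number from compound 1 to compound 3 (0.01 log units; within the scatter). The exchange of the whole benzyl for a cyclopentyl, from compound 1 to compound 2 and from compound 2 to compound 3, also stayed within the scatter. Nothing measured here shows this position moving the number beyond the scatter, so compound 4 is expected to stay close to compound 3, with an expected step of a 1.1-fold lower number from compound 3 to compound 4 (0.03 log units; within the scatter). The estimate for compound 4 in this assay is therefore 17000 nM, within a range of 8000 nM to 36000 nM.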

Compound 4, half-maximal inhibitory concentration: 12500 nM
Compound 4: middle estimate off by 1.4-fold (0.13 log units), on the high side, and the stated range covers the measured number.
By their numbers in this assay, from the lowest: compounds 2, 4, 1 and 3 (each within the scatter of the next).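

In this assay the exchange of aryl groups on the saturated chain carbon bound to an aromatic nitrogen now extends to a 2-(trifluoromethyl)phenyl group, which gave a 1.5-fold lower number from compound 3 to compound 4 (0.16 log units; within the scatter) against 3-chlorophenyl and a 1.4-fold lower number from compound 1 to compound 4 (0.15 log units; within the scatter) against 4-(trifluoromethyl)phenyl. Both steps lie within the scatter, so the three benzyl groups shown cannot be told apart, whichever of these substituents the aryl ring carries and wherever its name places it. The comparison with the non-aromatic group points the same way, with a 1.2-fold higher number from compound 2 to compound 4 (0.08 log units; within the scatter) on going from cyclopentyl to 2-(trifluoromethyl)benzyl on the aromatic nitrogen, and no evidence accompanies these numbers that could explain why this position has so far shown no step beyond the scatter.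

The compounds shown leave open whether an amine, a carboxylic acid or a longer chain on the aromatic nitrogen would move the number beyond the scatter. They also leave open whether any group at this position can do so at all, since every pair among the four compounds still lies within the scatter.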